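The source may report more compounds than this note shows. Statements on the series, on what has been measured and on what is new or still open speak of the compounds shown alone.

Measured so far in a functional assay on MDA-MB-231 cells (Homo sapiens) for inhibition, read by WST assay, with a stated time of 48 h; on this read-out lower numbers stand for stronger inhibition and higher numbers for weaker inhibition: compound 1 `O=[N+]([O-])c1cccc(/C=N\NC(=S)NC2CCCCC2)c1` gives 84800 nM; compound 2 `Oc1ccc(/C=N\NC(=S)NC2CCCCC2)cc1` gives 115000 nM; compound 3 `CCOc1ccc(/C=N\NC(=S)NC2CCCCC2)cc1` gives 68200 nM.

Compound 3 has the lowest of the three numbers, yet the other two lie within the usual scatter of it, so the three are not really separated. Compound 4 `CN(C)c1ccc(/C=N\NC(=S)NC2CCCCC2)cc1` differs from compound 3 in one place: dimethylamino in place of ethoxy on an aromatic carbon. Going by the values given here, the only step so far at the same place, a 1.7-fold lower number from compound 2 to compound 3 (0.23 log units; within the scatter), stayed within the scatter, so there is no sign that exchanging groups at this place moves the number. For compound 4 a step of a 1.0-fold lower number from compound 3 to compound 4 (0.02 log units; within the scatter) is therefore expected, no larger than the scatter. Compound 4 is estimated at 65000 nM, with a range from 25000 nM to 170000 nM.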

Compound 4, half-maximal inhibitory concentration: 125000 nM
For compound 4 the middle estimate is 1.9-fold (0.28 log units) below the measured one; the measured number falls inside the stated range.
By their numbers in this assay, from the lowest: compounds 3, 1, 2 and 4 (each within the scatter of the next).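

In this assay, dimethylamino in place of ethoxy on this aromatic carbon gives a step within the scatter (a 1.8-fold higher number from compound 3 to compound 4 (0.26 log units; within the scatter)), and so does dimethylamino in place of hydroxy (a 1.1-fold higher number from compound 2 to compound 4 (0.04 log units; within the scatter)). Hydroxy, ethoxy and dimethylamino at this place are therefore not told apart by this read-out, whether oxygen or nitrogen is the atom attached to the ring. Nothing at hand explains why these groups read alike. From the compounds shown here alone, it remains open whether a carboxylic acid, a primary amine or a longer chain such as butoxy at this place would give a step beyond the scatter.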